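Swapping the ester substituent in a dihydropyridine series

The source may hold more compounds than are shown below. What is called first, only, known or untested is meant among the compounds shown, and "the series" means these compounds.

Measured compounds:
Compound 1, `COC(=O)C1=C(C)NC(C)=C(C(=O)OC2C=CCCC2)C1c1cccc([N+](=O)[O-])c1`: 10 nM
Compound 2, `COC(=O)C1=C(C)NC(C)=C(C(=O)OCc2cc([N+](=O)[O-])cc([N+](=O)[O-])c2)C1c1cccc([N+](=O)[O-])c1`: 40 nM

Both compounds share one core and differ only in the group carried on the ester. In a functional assay on HEK293 cells for antagonist activity at Voltage-dependent L-type calcium channel subunit alpha-1D (Rattus norvegicus), read by FLIPR (a higher number here means a weaker inhibitor, a lower number a stronger inhibitor), compound 1 gives 10 nM, the lower of the two numbers. Compound 2, measured in this assay, gives 40 nM, the higher of the two numbers, and the gap to compound 1 is beyond the usual scatter of repeated measurements.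

Compound 3, `COC(=O)C1=C(C)NC(C)=C(C(=O)OCCc2ccc(Cl)cc2)C1c1cccc([N+](=O)[O-])c1`, has not yet been measured. It differs from compound 2 in one place: 4-chlorobenzyl in place of 3,5-dinitrophenyl on a saturated chain carbon bound to an oxygen next to a carbonyl group. Within the data shown here, no pair of measured compounds shows this exact change, so the step can only be judged from how the two measured numbers lie. Compound 1, which also carries a group without nitro substituents on the ester, sits lower than compound 2, and the step from compound 2 to compound 3 is expected to point in the same direction, toward a lower number, by a modest amount that may only just exceed the scatter: a 2.7-fold lower number from compound 2 to compound 3 (0.43 log units; beyond the scatter). For compound 3 in this assay the estimate is 15 nM, with a likely range from 4 nM to 60 nM.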

Compound 3, half-maximal inhibitory concentration: 39 nM
Estimate against measurement, compound 3: 2.6-fold (0.41 log units) below; the range from low to high includes it.
By their numbers in this assay, from the lowest: compound 1; then compounds 3 and 2 (each within the scatter of the next).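

In this assay, 4-chlorobenzyl in place of 3,5-dinitrophenyl on a saturated chain carbon bound to an oxygen next to a carbonyl group gives a 1.0-fold lower number from compound 2 to compound 3 (0.01 log units; within the scatter) and so leaves the reading unmoved, even though the entering group has no nitrogen or oxygen atoms and no hydrogen-bond acceptors. Losing the nitro groups therefore does not by itself bring the number down to that of compound 1: 2-(4-chlorophenyl)ethyl in place of cyclohex-2-en-1-yl on an oxygen next to a carbonyl group gives a 3.9-fold higher number from compound 1 to compound 3 (0.59 log units; beyond the scatter) and marks cyclohex-2-en-1-yl as the one ester group of the three that stands apart. Nothing measured here about these groups bears on this result.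

Still open, on these data alone, is whether a saturated cyclohexyl group on the same oxygen would read like compound 1, which would show if the ring double bond matters. Also open, as far as these compounds go, is how the reading would respond to an amine or a carboxylic acid on the ester chain, or to a longer chain carrying the 4-chlorophenyl ring.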